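The source may hold more compounds than are shown below. What is called first, only, known or untested is meant among the compounds shown, and "the series" means these compounds.

Measured compounds in an ADME assay on cells (Homo sapiens) for cytotoxicity, read by polymerase chain reaction, with a stated time of 3 days; on this read-out lower numbers stand for higher toxicity in this test and higher numbers for lower toxicity in this test:
- compound 1 `Nc1nc(Cl)c(-c2cc3ccccc3s2)c(N[C@@H]2C[C@H](CO)[C@@H](O)[C@H]2O)n1` gives > 25000 nM, a limit of the assay and not a number
- compound 2 `Nc1nc(Cl)c(-c2nc3ccccc3o2)c(N[C@@H]2C[C@H](CO)[C@@H](O)[C@H]2O)n1` gives 12000 nM
- compound 3 `Cc1nc(NC(C)C)nc(N[C@@H]2C[C@H](CO)[C@@H](O)[C@H]2O)c1-c1nc2ccccc2s1` gives 13000 nM

Among the compounds with values here, compound 3 holds the higher of the two numbers read so far in this assay; compound 2 stands nearest, and the gap between the two lies within the scatter, so no order between them can be claimed. Compound 1 sits at the limit of > 25000 nM in this assay, at which 1 of the 3 values shown sits.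

Within the data shown here, only one step is measured: an at least 2.0-fold lower number from compound 1 to compound 2 (0.31 log units; beyond the scatter). That step exchanges the aromatic group attached to the core while the amine substituent is unchanged, so it does not bear on the change examined here. Compounds 2 and 3 differ in several places at once and give numbers within the scatter of each other; nothing more can be read from that pair.

Compound 4 `Cc1nc(Nc2ccccc2)nc(N[C@@H]2C[C@H](CO)[C@@H](O)[C@H]2O)c1-c1nc2ccccc2s1` differs from compound 3 by phenyl in place of isopropyl on a nitrogen on an aromatic ring. Among the measured compounds shown here, no measured pair varies this nitrogen substituent, so there is no direct precedent for the size or direction of the step. The step from compound 3 to compound 4 in this assay is therefore expected to be a 1.3-fold lower number from compound 3 to compound 4 (0.11 log units; within the scatter), nothing beyond the scatter. Compound 4 is estimated at 10000 nM in this assay, with a range from 4000 nM to 25000 nM.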

Compound 4, half-maximal cytotoxic concentration: > 25000 nM
Compound 4: a limit, no number; the forecaster's own chance of this, stated with the estimate: 20%; middle value at least 2.5-fold (0.39 log units) away from the limit.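

Within the data shown here, at the nitrogen on an aromatic ring, the exchange of isopropyl for phenyl gives the first measured step in this assay that varies this substituent: an at least 1.9-fold higher number from compound 3 to compound 4 (0.28 log units; that floor lies within the scatter). Compound 4 gives > 25000 nM, which is a limit of the assay and not a number. The step therefore has a floor but no measured size, and the pair cannot be separated beyond the scatter on that floor alone, though phenyl on this nitrogen brings no sign of a lower number, and the series now has a second compound at the upper limit: the limit of > 25000 nM in this assay, at which 2 of the 4 values shown sit.

The compounds shown leave open how large the step from isopropylamino to anilino really is, and so whether it exceeds the scatter. They also leave open whether the higher reading goes with the aromatic ring itself or only with the loss of isopropyl, a question on which a cyclohexyl or benzyl group on this nitrogen, or a phenyl carrying an amine or a carboxylic acid, would bear.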